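A few compounds are considered here, and "the series" means these few. Any claim that something is new, unique, unknown or untested is made for them only; others in the source may bear on it.

Measured compounds:
compound 1 `CCOC(=O)NC(=O)NC1=CS(=O)(=O)O[C@@]12[C@@H](CO[Si](C)(C)C(C)(C)C)O[C@@H](n1cc(C)c(=O)n(C)c1=O)[C@@H]2O[Si](C)(C)C(C)(C)C`: 16000 nM
compound 3 `COC(=O)CC(=O)NC1=CS(=O)(=O)O[C@@]12[C@@H](CO[Si](C)(C)C(C)(C)C)O[C@@H](n1cc(C)c(=O)n(C)c1=O)[C@@H]2O[Si](C)(C)C(C)(C)C`: 400000 nM
compound 2 `Cc1cn([C@@H]2O[C@H](CO[Si](C)(C)C(C)(C)C)[C@@]3(OS(=O)(=O)C=C3NC(=O)c3ccccc3)[C@H]2O[Si](C)(C)C(C)(C)C)c(=O)n(C)c1=O`: its result is a limit of the assay, >= 3200 nM

In a functional assay on HEL cells (Homo sapiens) for cytotoxicity, read by microscopy (on this read-out higher numbers stand for lower toxicity in this test and lower numbers for higher toxicity in this test), compound 1 holds the lowest of the two readable numbers, the other being a 25-fold higher number from compound 1 to compound 3 (1.40 log units; beyond the scatter). For compound 2 the step from compound 1 cannot be read, since a step that the limit leaves unreadable from compound 1 to compound 2 rests on (the limit of >= 3200 nM in this assay, at which 1 of the 3 values shown sits).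

Compound 4 `CC(=O)NC1=CS(=O)(=O)O[C@@]12[C@@H](CO[Si](C)(C)C(C)(C)C)O[C@@H](n1cc(C)c(=O)n(C)c1=O)[C@@H]2O[Si](C)(C)C(C)(C)C` differs from compound 1 by methyl in place of (ethoxycarbonyl)amino on a carbonyl carbon. Among the measured compounds shown here, the one readable step on the same carbonyl carbon, from compound 1 to compound 3, was large and upward; the step to compound 2 is unreadable. Compound 4 is therefore expected to give a higher number than compound 1, though a smaller rise than compound 3 showed. The step expected for compound 4 is estimated at about a 3.8-fold higher number from compound 1 to compound 4 (0.57 log units; beyond the scatter). The estimate for compound 4 is 60000 nM, within 12000 nM to 320000 nM.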

Compound 4, minimum cytotoxic concentration: >= 80000 nM
Compound 4 ended at the assay's limit (the forecaster's own chance of this, stated with the estimate: 25%); middle value at least 1.3-fold (0.12 log units) away from the limit.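

In this assay compound 4 gives >= 80000 nM, which is a limit of the assay. Even so, the change reads as an at least 5.0-fold higher number from compound 1 to compound 4 (0.69 log units; beyond the scatter), so plain methyl on this carbonyl carbon, with no methoxycarbonyl, moves the number in the same direction as a 25-fold higher number from compound 1 to compound 3 (1.40 log units; beyond the scatter). The steps to compound 4 from compound 2 and compound 3 cannot be read, which leaves the order among methyl, phenyl and (methoxycarbonyl)methyl unsettled. Still open, going by these compounds, are the true value of compound 4 and whether an amine, a carboxylic acid or a longer alkyl chain on this carbonyl carbon would also give a higher number than compound 1.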